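Amide in Place of Benzyl: Cytotoxicity Notes

The compounds below may be only part of what the source reports. "The series", "measured", "known", "first", "only" and "open" are said of these compounds alone.

Measured compounds:
compound 1 `CCCCC(c1cc2ccc(C)cc2[nH]c1=O)N(Cc1ccc(F)cc1)Cc1ccc(C(C)C)cc1`
compound 2 `Cc1ccc2cc(CN(Cc3ccc(F)cc3)Cc3ccc(C(C)C)cc3)c(=O)[nH]c2c1`
compound 3 `Cc1ccc2cc(CN(Cc3ccc(C(C)C)cc3)Cc3cccc(F)c3)c(=O)[nH]c2c1`

In a toxicity assay on MDCK cells (Canis lupus familiaris) for cytotoxicity, read by crystal violet staining, with a stated time of 48 h (a higher number here means that more compound is tolerated, a lower number that less compound is tolerated), compound 1 gives > 33000 nM, which is a limit of the assay and not a number. Compound 2 gives > 33000 nM, likewise a limit. Compound 3 gives > 33000 nM, again a limit. Compound 2 therefore stands at the ceiling of what was tested, as described by the limit of > 33000 nM in this assay, at which 3 of the 3 values shown sit, and nothing separates it from its neighbours on these numbers. Going by the values given here, the two measured steps, a step that the two limits leave unreadable from compound 1 to compound 2 and a step that the two limits leave unreadable from compound 2 to compound 3, are both unreadable for the same reason, so the series so far carries no readable size of change at all.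

Compound 4 `Cc1ccc2cc(CN(Cc3ccc(F)cc3)C(=O)c3ccccc3)c(=O)[nH]c2c1` is reached from compound 2 by benzoyl in place of 4-isopropylbenzyl on an amine nitrogen. Neither measured step touches this nitrogen in the same way, and neither gives a usable size, so the expectation rests only on the three shared limits. Compound 4 is expected at 40000 nM, with a range from 15000 nM to 100000 nM, most probably reported once more as a limit. The expected step that the limit leaves unreadable from compound 2 to compound 4 is accordingly estimated to lie within the scatter.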

Compound 4, half-maximal cytotoxic concentration: > 33000 nM
Compound 4: a limit, no number; the forecaster's own chance of this, stated with the estimate: 75%; the middle value lies beyond the limit too.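

No size of step can be read between compound 2 and compound 4, since each result is a limit and not a number: the limit of > 33000 nM in this assay, at which 4 of the 4 values shown sit.

The compounds shown leave open how much compound these structures tolerate beyond that limit, and whether benzoyl and 4-isopropylbenzyl differ at all.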